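Removing one methoxy from the aryl ketone of compound 3

The source may hold more compounds than are shown below. What is called first, only, known or untested is meant among the compounds shown, and "the series" means these compounds.

Compound 3 `COc1ccc(C(=O)/C=C/c2cc(-c3cc(OC)c(OC)c(OC)c3)n[nH]2)cc1OC` gives 1590 nM in a functional assay on OVCAR-5 cells (Homo sapiens) for inhibition, read by sulforhodamine B assay, with a stated time of 48 h (a lower number here means a stronger inhibitor of growth, a higher number a weaker inhibitor of growth), the low end of the three numbers, with compound 1 `COc1cc(-c2cc(/C=C/C(=O)c3ccc(N)cc3)[nH]n2)cc(OC)c1OC` at 1780 nM not separable from it, while compound 2 `COc1cc(-c2cc(/C=C/C(=O)c3ccc(Cl)c(Cl)c3)[nH]n2)cc(OC)c1OC` gives 20500 nM. The step of a 1.1-fold lower number from compound 1 to compound 3 (0.05 log units; within the scatter) lies within the scatter, whereas a 13-fold lower number from compound 2 to compound 3 (1.11 log units; beyond the scatter) and a 12-fold higher number from compound 1 to compound 2 (1.06 log units; beyond the scatter) are large. Compound 4 `COc1ccc(C(=O)/C=C/c2cc(-c3cc(OC)c(OC)c(OC)c3)n[nH]2)cc1` differs from compound 3 by hydrogen in place of methoxy on an aromatic carbon. Within the data shown here, no measured step swaps a methoxy for hydrogen on this ring, so none bears directly; the same ring tolerates one exchange without effect and another with a large one. The expected step of a 1.6-fold higher number from compound 3 to compound 4 (0.20 log units; within the scatter) is therefore small, most likely within the scatter, leaning toward a higher number. Compound 4 is estimated at 2500 nM, within a range of 800 nM to 8000 nM.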

Compound 4, concentration for 50% growth inhibition: 1880 nM
Beside the measured number, compound 4's estimate is 1.3-fold (0.12 log units) above it; the measured number falls inside the stated range.
By their numbers in this assay, from the lowest: compounds 3, 1 and 4 (each within the scatter of the next); then compound 2.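

In this assay the loss of a methoxy from this ring can now be read directly: a 1.2-fold higher number from compound 3 to compound 4 (0.07 log units; within the scatter) leaves the 3,4-dimethoxyphenyl and 4-methoxyphenyl ketones not separable. Methoxy in place of amino on the ring gives a 1.1-fold higher number from compound 1 to compound 4 (0.02 log units; within the scatter), also not separable, while an 11-fold lower number from compound 2 to compound 4 (1.04 log units; beyond the scatter) is large, so only the 3,4-dichlorophenyl ketone of compound 2 stands apart among the four. No supporting evidence accounts for these steps. From the compounds shown here alone, whether an ethoxy or a carboxylic acid in place of the remaining methoxy would keep the number in this range stays open.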